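Substituting a primary amine on the shared core of compound 2

The source may report more compounds than this note shows. Statements on the series, on what has been measured and on what is new or still open speak of the compounds shown alone.

The three measured compounds share one core, carrying a chain on the central amine nitrogen. Compound 1, `CC(C)(CCN)CN(C[C@H]1Cc2ccccc2CN1)[C@H]1CCCc2cccnc21`, is measured in a functional assay on cells for agonist activity at C-X-C chemokine receptor type 4 (Homo sapiens), read by fluorescence and calcium flux, with a stated time of 90 s; on this read-out higher numbers stand for an effect only at larger amounts of compound and lower numbers for an effect already at smaller amounts. In this assay compound 1 reaches only the limit > 30000 nM, a boundary of the assay and not a number. Compound 2, `CC(C)(CN)CCN(C[C@H]1Cc2ccccc2CN1)[C@H]1CCCc2cccnc21`, gives in this assay the limit > 30000 nM, again a boundary rather than a number. Compound 3, `C(=C/CN(C[C@H]1Cc2ccccc2CN1)[C@H]1CCCc2cccnc21)\CNC1CCOCC1`, also sits in this assay at the limit > 30000 nM, which is a boundary and not a number. Accordingly the three steps, a step that the two limits leave unreadable from compound 1 to compound 2, a step that the two limits leave unreadable from compound 1 to compound 3 and a step that the two limits leave unreadable from compound 2 to compound 3, cannot be read in size or direction, because of the limit of > 30000 nM in this assay, at which 3 of the 3 values shown sit.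

The unmeasured compound 4, `CC(C)(CCN(C[C@H]1Cc2ccccc2CN1)[C@H]1CCCc2cccnc21)CNC1CCC(F)(F)CC1`, differs from compound 2 by 4,4-difluorocyclohexyl in place of hydrogen on an amine nitrogen. Among the measured compounds shown here, no measured step bears on this change, since every comparison among compounds 1, 2 and 3 is hidden behind the same limit; compound 3, which carries a related substituted amine, also stands at that limit. The expectation for compound 4 is therefore a step that the limit leaves unreadable from compound 2 to compound 4, most likely ending again at the limit rather than at a number. The estimate for compound 4 is 40000 nM, within a range from 8000 nM to 200000 nM.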

Compound 4, half-maximal effective concentration: > 30000 nM
Compound 4: a limit, no number; the forecaster's own chance of this, stated with the estimate: 75%; the middle value is on the limit's open side.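

In this assay compound 4 gives > 30000 nM, a limit and not a number. No size or direction can be read for the change from compound 2 to compound 4, because both stop at the same boundary: the limit of > 30000 nM in this assay, at which 4 of the 4 values shown sit.

The compounds shown leave open whether 4,4-difluorocyclohexyl on this amine nitrogen changes the effect at all.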